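A Ring Oxygen for a Ring Nitrogen on the Amide

This account rests on a few compounds, and the source may have more. Where it says the series, first, only, none or still open, it means among the compounds named here.

Measured so far:
compound 1 `Nc1sc(-c2ccc(Cl)cc2)c(-c2ccc(Cl)cc2)c1C(=O)N1CCNCC1`: 2710 nM
compound 2 `Nc1sc(-c2ccc(Cl)cc2)c(-c2ccc(Cl)cc2)c1C(=O)NCc1ccccc1`: 31800 nM

In a functional assay on PC-3 cells (Homo sapiens) for inhibition, read by sulforhodamine B assay, with a stated time of 72 h (a higher number here means a weaker inhibitor, a lower number a stronger inhibitor), compound 1 gives 2710 nM, the lowest of the two numbers recorded. Compound 2 gives 31800 nM. Within the data shown here, the single measured step, a 12-fold higher number from compound 1 to compound 2 (1.07 log units; beyond the scatter), is large and lies beyond the scatter.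

Compound 3 `Nc1sc(-c2ccc(Cl)cc2)c(-c2ccc(Cl)cc2)c1C(=O)N1CCOCC1` differs from compound 1 in one place: morpholin-4-yl in place of piperazin-1-yl on a carbonyl carbon. The step from compound 1 to compound 2 is the only one that bears on it, since both steps alter the group on the carbonyl carbon. That step, however, swapped the whole six-membered non-aromatic ring for a benzylamino group, whereas compound 3 keeps a six-membered non-aromatic ring with 2 hetero atoms and gives up only the hydrogen-bond donor. A weaker number is therefore expected for compound 3, but a smaller loss than that seen with compound 2.

Compound 3 is expected to give about 7000 nM, with a range from 2500 nM to 25000 nM. The estimated step, a 2.6-fold higher number from compound 1 to compound 3 (0.41 log units; beyond the scatter), is expected to fall between the scatter and the benzylamino loss.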

Compound 3, half-maximal inhibitory concentration: 11700 nM
The estimate for compound 3 lay 1.7-fold (0.22 log units) below the measured number, within the range that was stated.
By their numbers in this assay, from the lowest: compound 1; then compound 3; then compound 2.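

In this assay, keeping a six-membered non-aromatic ring on the carbonyl carbon does not by itself hold the number: morpholin-4-yl in place of piperazin-1-yl gives a 4.3-fold higher number from compound 1 to compound 3 (0.64 log units; beyond the scatter). The ring still counts for something, since morpholin-4-yl in place of benzylamino gives a 2.7-fold lower number from compound 2 to compound 3 (0.43 log units; beyond the scatter), so all three groups on this carbonyl carbon stand apart beyond the scatter, with piperazin-1-yl lowest. No measurement available here accounts for these differences.

Going by these compounds, it remains open whether the loss follows the ring oxygen itself or the missing hydrogen-bond donor, a question that 4-methylpiperazin-1-yl or thiomorpholin-4-yl could help to separate. On these data alone, it is also open how an open-chain amine such as dimethylamino would stand against these ring groups on the same carbonyl carbon.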